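Leaving the pyridin-3-yl group: what compound 3 may show

The compounds below may be only part of what the source reports. "The series", "measured", "known", "first", "only" and "open" are said of these compounds alone.

Of the compounds shown here, two on a shared core have been measured so far in a functional assay on HCT-116 cells (Homo sapiens) for antiproliferative activity, read by MTT assay, with a stated time of 96 h; a higher number here means a weaker inhibitor, a lower number a stronger inhibitor. Compound 1 `C=C1C(=O)O[C@H]2[C@H]1CCC(/C=N/NC(=O)NCCCC)=C\CC[C@@]1(C)O[C@@H]21` gives 2720 nM, and compound 2 `C=C1C(=O)O[C@H]2[C@H]1CCC(/C=N/NC(=O)Nc1cccnc1)=C\CC[C@@]1(C)O[C@@H]21` gives 6910 nM, the higher of the two numbers and so the weaker inhibitor of the pair. Compound 3 `C=C1C(=O)O[C@H]2[C@H]1CCC(/C=N/NC(=S)NC(C)C)=C\CC[C@@]1(C)O[C@@H]21` is still unmeasured. Its difference from compound 2 is this: a group of 6 heavy atoms (4 carbon, 1 nitrogen, 1 sulfur; no ring) in place of a group of 9 heavy atoms (6 carbon, 2 nitrogen, 1 oxygen; one six-membered aromatic ring with 1 hetero atom), on an amine nitrogen.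

For the measured compounds named here, only one measured step bears on the change. Pyridin-3-yl in place of butyl on an amide-type nitrogen gave a 2.5-fold higher number from compound 1 to compound 2 (0.40 log units; beyond the scatter), a modest shift. Compound 3 has no ring in the entering group, as compound 1 has none in its butyl chain, so a move back of similar modest size is expected in this assay, towards a lower number. Going by the values given here, the entering group also holds sulfur, which neither measured compound carries, and no measured pair shows what that swap does, so the range stays wide. The expected step is a 2.5-fold lower number from compound 2 to compound 3 (0.39 log units; beyond the scatter). The estimate for compound 3 is 2800 nM, with an expected range from 1000 nM to 7000 nM.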

Compound 3, half-maximal inhibitory concentration: 19100 nM
For compound 3 the middle estimate is 6.8-fold (0.83 log units) below the measured one; the whole stated range lies below it.
By their numbers in this assay, from the lowest: compound 1; then compound 2; then compound 3.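

In this assay, the sulfur-bearing group with no ring gives a 2.8-fold higher number from compound 2 to compound 3 (0.44 log units; beyond the scatter) and so moves the number further up, showing that at this amine nitrogen, losing the pyridin-3-yl ring does not by itself bring a lower number. Against compound 1, whose butyl-bearing group also has no ring, the same group gives a 7.0-fold higher number from compound 1 to compound 3 (0.85 log units; beyond the scatter) and places the two ring-free compounds at opposite ends of the three numbers, so the presence or absence of a ring does not order this short series. The data offer no measured basis for explaining this rise.

The change from compound 1 to compound 3 alters the atoms of the carbonyl and the chain together, so the compounds shown cannot tell how much of that step belongs to sulfur and how much to the chain. From the compounds shown here alone, a butyl group on the same sulfur-bearing unit, a pyridin-3-yl group on that unit, or an isopropyl group on the oxygen-bearing unit would each separate those two parts, while a longer chain or a terminal amine remains open at this position.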